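Swapping hydroxy and methoxy on one ring

The source may report more compounds than this note shows. Statements on the series, on what has been measured and on what is new or still open speak of the compounds shown alone.

Compound 1 `COc1cccc(/C=C/C(=O)C(=Cc2cc(OC)c(OC)c(OC)c2)C(=O)/C=C/c2cccc(OC)c2OC)c1OC` gives 400 nM
Compound 2 `COc1cccc(/C=C/C(=O)C(=Cc2ccc(OC)c(OC)c2OC)C(=O)/C=C/c2cccc(OC)c2OC)c1OC` gives 410 nM
Compound 3 `COc1ccc(/C=C/C(=O)C(=Cc2ccc(O)c(OC)c2)C(=O)/C=C/c2ccc(OC)cc2OC)c(OC)c1` gives 970 nM

In a functional assay on CNE-2 cells (Homo sapiens) for antiproliferative activity, read by sulforhodamine B assay, with a stated time of 48 h (a higher number here means a weaker inhibitor, a lower number a stronger inhibitor), compound 3 gives 970 nM as the highest of the three numbers, which makes it the weakest inhibitor here. Its gap to each of the other two lies beyond the usual scatter, but compound 3 differs from them in more than one place, so those gaps do not isolate any single change.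

Compound 4 `COc1ccc(/C=C/C(=O)C(=Cc2ccc(OC)c(O)c2)C(=O)/C=C/c2ccc(OC)cc2OC)c(OC)c1` has the same atoms as compound 3, joined differently. The difference is 3-hydroxy-4-methoxyphenyl in place of 4-hydroxy-3-methoxyphenyl on a double-bonded chain carbon bound to a double-bonded chain carbon and amounts to 3-hydroxy-4-methoxyphenyl in place of 4-hydroxy-3-methoxyphenyl on a double-bonded chain carbon bound to a double-bonded chain carbon.

One measured step is of a related kind, a rearrangement of groups on the ring at this same place. It is a 1.0-fold higher number from compound 1 to compound 2 (0.01 log units; within the scatter) and it exchanges 3,4,5-trimethoxyphenyl for 2,3,4-trimethoxyphenyl. Within the data shown here, that step moves only methoxy groups, and no measured pair moves a hydroxy group, so the guide is thin.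

In this assay the expected result is a 1.1-fold lower number from compound 3 to compound 4 (0.03 log units; within the scatter) with no change beyond the scatter expected in either direction. Compound 4 is estimated at 900 nM (400 nM to 2000 nM).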

Compound 4, half-maximal inhibitory concentration: 760 nM
Compound 4: middle estimate off by 1.2-fold (0.07 log units), on the high side, within the range that was stated.
By their numbers in this assay, from the lowest: compounds 1, 2, 4 and 3 (each within the scatter of the next, the first and the last beyond it).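

Among these compounds, the step from compound 1 to compound 2 rearranged only methoxy groups, so this pair is the first to test moving a hydroxy group on the ring at this place. In this assay, exchanging 4-hydroxy-3-methoxyphenyl for 3-hydroxy-4-methoxyphenyl gives a 1.3-fold lower number from compound 3 to compound 4 (0.11 log units; within the scatter), so the two arrangements cannot be told apart in this measurement, and within this pair the exact placement of the hydroxy and methoxy groups makes no clear difference. No accompanying measurement bears on this result, so the compounds shown offer no explanation of it.

The compounds shown do not reveal whether the hydroxy group matters at all, since neither compound 3 nor compound 4 has a direct partner with a different group there, such as an amine or a carboxylic acid. Compounds 3 and 4 also differ from compounds 1 and 2 in more than one place, which leaves open whether the same exchange would give a similarly small step if the other two rings were those of compound 1.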